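Removing an Acetyl Group from Two Related Cores

The source may report more compounds than this note shows. Statements on the series, on what has been measured and on what is new or still open speak of the compounds shown alone.

Of the compounds shown here, three have been measured in a functional assay on HEp-2 cells (Homo sapiens) for inhibition (a lower number here means a stronger inhibitor, a higher number a weaker inhibitor), and a fourth awaits measurement. Compound 1 `CC(O)n1cnc2c(N)nc(I)nc21` and compound 2 `CC(=O)OC(C)n1cnc2c(N)nc(I)nc21` share one core; compound 2 carries an acetyl on its oxygen, where compound 1 carries a hydrogen. In this assay compound 1 gives > 500000 nM, which is a limit of the assay and not a number. Compound 2 likewise gives > 500000 nM, again a limit. The change from compound 2 to compound 1, (hydrogen in place of acetyl on an oxygen on a saturated carbon), therefore produces a step that the two limits leave unreadable from compound 2 to compound 1 that cannot be read because the limit of > 500000 nM in this assay, at which 2 of the 3 values shown sit, covers both of them.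

Compound 3 `CC(=O)OC(C)n1cnc2c(S)nc(F)nc21` is built on a different core; the difference between the two cores is not broken down here. In this assay, going by the values given here, compound 3 gives 200000 nM, the only plain number among the three measured values. Compound 4 `CC(O)n1cnc2c(S)nc(F)nc21` is compound 3 with the same change applied: hydrogen in place of acetyl on an oxygen on a saturated carbon.

Among the compounds with values here, since the one measured instance of this change has no readable size, the expectation for compound 4 rests on compound 3 alone, whose value of 200000 nM is taken as the starting point. The step expected is a 1.5-fold higher number from compound 3 to compound 4 (0.18 log units; within the scatter), essentially no movement. Compound 4 is expected to give about 300000 nM, most likely between 100000 nM and 800000 nM, with a real chance that only a limit is reported.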

Compound 4, half-maximal inhibitory concentration: > 500000 nM
Compound 4: a limit, no number (the forecaster's own chance of this, stated with the estimate: 40%); at least 1.6-fold (0.22 log units) between middle value and limit.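

In this assay, going from acetoxy to hydroxy on the core of compound 3 gives an at least 2.5-fold higher number from compound 3 to compound 4 (0.39 log units; beyond the scatter), so on this core, removing the acetyl weakens inhibition by more than the usual scatter. Compound 4 gives > 500000 nM, which is a limit of the assay and not a number, so the step has a known minimum but no known full size. This does not show that the change behaves the same way on both cores, since the matching step on the core of compound 1 cannot be read and only one readable instance remains, because the values of both compounds on that core sit at one shared limit: the limit of > 500000 nM in this assay, at which 3 of the 4 values shown sit.

The compounds shown leave open whether any group on this oxygen could bring the number well below the values seen here on either core, since all four carry only an acetyl or a hydrogen there. A longer chain in place of the acetyl, such as a butanoyl group, or an amine in place of the hydroxy, would be a further test of how much this position matters.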